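This account rests on a few compounds, and the source may have more. Where it says the series, first, only, none or still open, it means among the compounds named here.

Measured compounds:
compound 1, `COc1cc(OC)c(OC)cc1/C=C/C(=O)c1cc(OC(C)=O)ccc1OC(C)=O`, 2.37 ug/mL
compound 2, `COc1cc(OC)c(-c2cc(=O)c3cc(O)ccc3o2)cc1OC`, 2.14 ug/mL

In a functional assay, read by Griess assay, with a stated time of 2.5 h (a lower number here means a stronger inhibitor, a higher number a weaker inhibitor), compound 1 gives 2.37 ug/mL. In this assay compound 2 gives 2.14 ug/mL. The two numbers sit side by side: the gap between compound 1 and compound 2 lies within the scatter, so neither can be set above the other on what is shown.

Compound 3, `COc1cc(OC)c(-c2cc(=O)c3cc(Cl)ccc3o2)cc1OC`, is not yet measured in this assay. Its structure differs from that of compound 2 in one place: chloro in place of hydroxy on an aromatic carbon. Among the compounds with values here, no measured pair shows this kind of exchange, so the size of the step cannot be read from the data. Within the data shown here, the account rests only on the two values so far, which both lie near each other, and the change is a single heavy atom on the same ring position. The step of a 1.4-fold higher number from compound 2 to compound 3 (0.15 log units; within the scatter) is expected to be small, most likely within the scatter, with a slight chance of a weaker number. Compound 3 is estimated at 3 ug/mL, within a range from 1 ug/mL to 9 ug/mL.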

Compound 3, half-maximal inhibitory concentration: 2.15 ug/mL
Compound 3: the middle estimate sits 1.4-fold (0.14 log units) above what was measured; the range from low to high includes it.
By their numbers in this assay, from the lowest: compounds 2, 3 and 1 (each within the scatter of the next).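

In this assay, within the data shown here, chloro in place of hydroxy on an aromatic carbon gives a 1.0-fold higher number from compound 2 to compound 3 (0.00 log units; within the scatter), the first exchange at this position that can be read. The hydroxy, with its hydrogen-bond donor and acceptor, can therefore leave this position and chloro, with neither, can enter while the number stays within the scatter. Nothing available explains why the two groups read alike.

The compounds shown leave open whether an amine or a carboxylic acid on this aromatic carbon would also stay within the scatter of compound 2 or would move the number beyond it. They also leave open whether the exchange of hydroxy for chloro would read the same if the methoxy groups of the shared core gave way to ethoxy groups.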